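This account rests on a few compounds, and the source may have more. Where it says the series, first, only, none or still open, it means among the compounds named here.

Measured compounds in an ADME assay on HPC cells (Homo sapiens) for cytotoxicity, with a stated time of 24 h; on this read-out lower numbers stand for higher toxicity in this test and higher numbers for lower toxicity in this test:
Compound 1 `O=C1/C(=C/c2ccc(F)cc2)CCC/C1=C\c1ccccc1[N+](=O)[O-]`: 11000 nM.
Compound 2 `Cc1ccc(/C=C2\CCC/C(=C\c3ccccc3[N+](=O)[O-])C2=O)cc1`: > 400000 nM, which is a limit of the assay.
Compound 3 `O=C1/C(=C/c2ccccc2)CCC/C1=C\c1ccc([N+](=O)[O-])cc1`: 123000 nM.

Of the two actual numbers, compound 3 at 123000 nM is the higher, and compound 1 at 11000 nM lies lower, with the gap beyond the scatter. The value for compound 2 is a limit, so it gives no number to rank against.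

Compound 4 `CN(C)c1ccc(/C=C2\CCC/C(=C\c3ccc([N+](=O)[O-])cc3)C2=O)cc1` differs from compound 3 by dimethylamino in place of hydrogen on an aromatic carbon, para to a large group (dimethylamino in place of hydrogen on an aromatic carbon). The same change reads as phenyl to 4-(dimethylamino)phenyl.

Among the measured compounds shown here, only one measured step bears on this, and only loosely: an at least 36-fold higher number from compound 1 to compound 2 (1.56 log units; beyond the scatter), a large step, for methyl in place of fluoro on an aromatic carbon. It involves a different exchange on a different parent, so it gives no firm direction. It does show that a single substituent change in this series can move the number well beyond the scatter. No replacement of hydrogen by dimethylamino has been measured.

A moderate move towards a lower number in this assay is expected, with low confidence in the direction, as compound 3 at 123000 nM already sits high among the numbers. The expected step is a 2.1-fold lower number from compound 3 to compound 4 (0.31 log units; beyond the scatter). For compound 4 the estimated value is 60000 nM, with an expected range of 10000 nM to 300000 nM.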

Compound 4, half-maximal cytotoxic concentration: > 400000 nM
Compound 4 was reported as a limit; the forecaster's own chance of this, stated with the estimate: 15%; middle value at least 6.6-fold (0.82 log units) away from the limit.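

In this assay, among the compounds shown here, the result gives the first reading for a substituent at this place on the phenyl ring of compound 3, on an aromatic carbon para to a large group: dimethylamino in place of hydrogen gives an at least 3.2-fold higher number from compound 3 to compound 4 (0.51 log units; beyond the scatter). For the compounds shown here, the only earlier step was an exchange of one substituent for another on a different parent, so this is the first sign that adding a group to the unsubstituted phenyl of compound 3 can shift the number towards lower toxicity in this test. Compound 4 gives > 400000 nM, which is a limit of the assay, so the step fixes a direction and a minimum size but no end point: the limit of > 400000 nM in this assay, at which 2 of the 4 values shown sit.

From the compounds shown here alone, whether methoxy, a primary amine or a carboxylic acid at the same place would move the number in the same direction, or whether the shift is particular to dimethylamino, remains open. Also open, going by these compounds, is whether dimethylamino would give a comparable step on a parent carrying its nitro group as in compound 1.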